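The source may hold more compounds than are shown below. What is called first, only, known or untested is meant among the compounds shown, and "the series" means these compounds.

Measured compounds in an assay on isolated protein for inhibition of microsomal triglyceride transfer protein large subunit (Homo sapiens); a lower number here means a stronger inhibitor, a higher number a weaker inhibitor:
compound 1 `CC(=O)NC1Cc2ccc(NC(=O)c3ccccc3-c3ccc(C(F)(F)F)cc3)cc2C1`, 80 nM
compound 2 `O=C(NC1Cc2ccc(NC(=O)c3ccccc3-c3ccc(C(F)(F)F)cc3)cc2C1)c1ccccc1`, > 1000 nM
compound 3 `CN(C)C(=O)NC1Cc2ccc(NC(=O)c3ccccc3-c3ccc(C(F)(F)F)cc3)cc2C1`, 80 nM

The entry for compound 2 is a limit of this assay, not a number (the limit of > 1000 nM in this assay, at which 1 of the 3 values shown sits). Compound 3 stands level with compound 1, within the scatter. Two steps on the same carbonyl carbon are known: phenyl for methyl gave an at least 12-fold higher number from compound 1 to compound 2 (1.09 log units; beyond the scatter), dimethylamino for methyl gave no change at the digits printed from compound 1 to compound 3 (within the scatter). Compound 4 `O=C(Nc1ccc2c(c1)CC(NCc1ccccc1)C2)c1ccccc1-c1ccc(C(F)(F)F)cc1` differs from compound 3 by benzyl in place of dimethylcarbamoyl on an amine nitrogen. Going by the values given here, no measured step removes the carbonyl itself, so the step is only partly covered; an aromatic ring at this end of the core went with an at least 12-fold higher number from compound 1 to compound 2 (1.09 log units; beyond the scatter). Compound 4 is therefore expected to be weaker, by a 5.0-fold higher number from compound 3 to compound 4 (0.70 log units; beyond the scatter). The estimate for compound 4 is 400 nM, with a range of 100 nM to 2000 nM.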

Compound 4, half-maximal inhibitory concentration: 4800 nM
Estimate against measurement, compound 4: 12-fold (1.08 log units) below; the measured number lies above the stated range.
By their numbers in this assay, from the lowest: compounds 1 and 3 (each within the scatter of the next); then compound 4.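

In this assay, benzyl on the amine nitrogen gives a 60-fold higher number from compound 3 to compound 4 (1.78 log units; beyond the scatter) and a 60-fold higher number from compound 1 to compound 4 (1.78 log units; beyond the scatter). Compound 4 is the first compound shown without a carbonyl on this nitrogen, and the dimethylcarbamoyl and acetyl groups, which both carry one, stand level. Compound 2 carries a limit, so its step to compound 4 cannot be read: the limit of > 1000 nM in this assay, at which 1 of the 4 values shown sits.

Because benzyl both removes the carbonyl and brings an aromatic ring, the compounds shown do not separate these two changes. As far as these compounds go, a free amine or a small methyl group on this nitrogen remains open.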